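Piperazine in Place of the Bicyclic Amine on the Aryl Ring

The compounds below may be only part of what the source reports. "The series", "measured", "known", "first", "only" and "open" are said of these compounds alone.

Measured compounds:
compound 1 `c1cnc2c(c1)CCC[C@@H]2N(CC1CC1)C[C@H]1Cc2c(cccc2N2CCNCC2)CN1`, 26.7 nM
compound 2 `CN(C[C@H]1Cc2c(cccc2N2CCN3CCC[C@H]3C2)CN1)[C@H]1CCCc2cccnc21`, 2.92 nM
compound 3 `CN(C[C@H]1Cc2c(cccc2N2CCN3CCC[C@@H]3C2)CN1)[C@H]1CCCc2cccnc21`, 3.59 nM

In a functional assay on CCRF-CEM cells for antagonist activity at C-X-C chemokine receptor type 4 (Homo sapiens), read by calcium flux, with stated times of 25 min and 90 s (on this read-out lower numbers stand for stronger inhibition and higher numbers for weaker inhibition), compound 3 gives 3.59 nM, the second highest of the three numbers: compound 2 stands nearest to it and compound 1 furthest. For the measured compounds named here, the single measured step, a 1.2-fold higher number from compound 2 to compound 3 (0.09 log units; within the scatter), rests on the fact that compounds 2 and 3 differ only in the configuration as drawn and shows that the configuration drawn within that group leaves the number unchanged. Compound 4 `CN(C[C@H]1Cc2c(cccc2N2CCNCC2)CN1)[C@H]1CCCc2cccnc21` differs from compound 3 in one place: a group of 6 heavy atoms (4 carbon, 2 nitrogen; one six-membered non-aromatic ring with 2 hetero atoms) in place of a group of 9 heavy atoms (7 carbon, 2 nitrogen; one five-membered non-aromatic ring with 1 hetero atom, one six-membered non-aromatic ring with 2 hetero atoms), on an aromatic carbon. Compound 1 also carries piperazin-1-yl, but it differs from compound 3 in a second place too, so its higher number cannot be laid on the piperazin-1-yl alone. Going by the values given here, no measured step covers this change directly. A modest weakening is expected, a 2.2-fold higher number from compound 3 to compound 4 (0.35 log units; beyond the scatter). Compound 4 is therefore estimated at 8 nM, within 2.5 nM to 25 nM.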

Compound 4, half-maximal inhibitory concentration: 6.08 nM
Estimate against measurement, compound 4: 1.3-fold (0.12 log units) above, within the range that was stated.
By their numbers in this assay, from the lowest: compounds 2, 3 and 4 (each within the scatter of the next, the first and the last beyond it); then compound 1.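

Piperazin-1-yl in place of the bicyclic group on the aromatic carbon stays within the scatter by one comparison (a 1.7-fold higher number from compound 3 to compound 4 (0.23 log units; within the scatter)) and is modest by the other (a 2.1-fold higher number from compound 2 to compound 4 (0.32 log units; beyond the scatter)), so the five-membered ring and its stereocentre are not required for a low number. With piperazin-1-yl held constant, hydrogen in place of cyclopropyl on the saturated chain carbon can now be read alone (a 4.4-fold lower number from compound 1 to compound 4 (0.64 log units; beyond the scatter)). Nothing given here explains these steps. Going by these compounds, whether morpholin-4-yl or 4-methylpiperazin-1-yl would hold the number on this aromatic carbon remains open.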